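From difluoromethoxy to pentyl on the shared core

The source may report more compounds than this note shows. Statements on the series, on what has been measured and on what is new or still open speak of the compounds shown alone.

Measured in a functional assay on HT-29 cells (Homo sapiens) for antiproliferative activity, read by sulforhodamine B assay, with a stated time of 48 h; on this read-out lower numbers stand for stronger inhibition and higher numbers for weaker inhibition:
compound 1 `O=C1NCCN1c1ccc(S(=O)(=O)Nc2ccc(Cl)cc2)cc1`: 220 nM
compound 2 `O=C1NCCN1c1ccc(S(=O)(=O)Nc2ccc(OC(F)F)cc2)cc1`: 650 nM

Of these two, compound 2 gives the higher number at 650 nM, which makes it the weaker inhibitor of the pair in this assay. The unmeasured compound 3 `CCCCCc1ccc(NS(=O)(=O)c2ccc(N3CCNC3=O)cc2)cc1` keeps the shared core and changes one group: pentyl in place of difluoromethoxy on an aromatic carbon. Pentyl thus takes the place of difluoromethoxy on an aromatic carbon.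

For the measured compounds named here, only one measured step bears on this place: a 3.0-fold higher number from compound 1 to compound 2 (0.47 log units; beyond the scatter), a modest step beyond the scatter, with difluoromethoxy in place of chloro. Going by the values given here, no measured compound carries pentyl, so the data offer no direct reading of that group. Among the compounds with values here, with so little to go on, and with the one step at this place being modest, a large change in this assay is not expected. A small move towards the lower number of compound 1 seems the likeliest outcome, and it may stay within the scatter. The expected step is a 1.6-fold lower number from compound 2 to compound 3 (0.21 log units; within the scatter). For compound 3 the estimated value is 400 nM, with an expected range from 100 nM to 1500 nM.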

Compound 3, half-maximal inhibitory concentration: 990 nM
Estimate against measurement, compound 3: 2.5-fold (0.39 log units) below; the measured number falls inside the stated range.
By their numbers in this assay, from the lowest: compound 1; then compounds 2 and 3 (each within the scatter of the next).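

In this assay, pentyl in place of difluoromethoxy on this aromatic carbon, para to a large group, gives a 1.5-fold higher number from compound 2 to compound 3 (0.18 log units; within the scatter) and so stays within the scatter: a chain of carbon alone and a group carrying oxygen and fluorine cannot be told apart at this position in this read-out. Set against chloro, the same pentyl gives a 4.5-fold higher number from compound 1 to compound 3 (0.65 log units; beyond the scatter) beyond the scatter, so both replacements shown, difluoromethoxy and pentyl, leave compound 1 with the lowest number of the three, and the position is shown to respond to chloro's removal rather than to the difference between these two replacements. Nothing measured here accounts for this outcome.

The compounds shown leave open whether any other group at this position, such as a methyl, a longer chain, an amine or a carboxylic acid, would match or pass chloro. They also leave open whether the same order would hold on other cell lines or with a change elsewhere on the shared core.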